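The source may hold more compounds than are shown below. What is called first, only, known or untested is meant among the compounds shown, and "the series" means these compounds.

Measured compounds:
- Compound 1, `Cc1cc(NC(=O)Nc2cccc(Cl)c2)c2ccccc2n1`: in an ADME assay on BJ cells (Homo sapiens) for cytotoxicity, with a stated time of 72 h (a higher number here means that more compound is needed for the effect, a lower number that less compound is needed), compound 1 reaches only the limit > 25000 nM.
- Compound 2, `Cc1cc(NC(=O)Nc2ccc(F)cc2)c2ccccc2n1`: in this assay compound 2 likewise reaches only the limit > 25000 nM.
- Compound 3, `Cc1cc(NC(=O)Nc2ccc(F)c(F)c2)c2ccccc2n1`: in this assay compound 3 also reaches only the limit > 25000 nM.

Compound 2 thus stands at the limit of this assay, and the two other values shown are limits as well. Both measured steps that touch the series, a step that the two limits leave unreadable from compound 1 to compound 2 and a step that the two limits leave unreadable from compound 2 to compound 3, are unreadable, since (the limit of > 25000 nM in this assay, at which 3 of the 3 values shown sit).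

The new compound 4, `Cc1cc(NC(=O)Nc2ccc(N(C)C)cc2)c2ccccc2n1`, differs from compound 2 at one point: dimethylamino in place of fluoro on an aromatic carbon.

Neither measured step gives a readable size, so the change to dimethylamino cannot be anchored to a measured effect. Given that every value shown sits at the limit, the expectation is that compound 4 also shows no cytotoxicity within range, with an expected step that the limit leaves unreadable from compound 2 to compound 4 that is not readable against a limit. Compound 4 is therefore estimated at 35000 nM, with a range from 12000 nM to 100000 nM.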

Compound 4, half-maximal effective concentration: > 25000 nM
Compound 4: a limit, no number (the forecaster's own chance of this, stated with the estimate: 80%); the middle value does not contradict the limit.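

The step between compound 2 and compound 4 cannot be read, since both compounds give only a limit: the limit of > 25000 nM in this assay, at which 4 of the 4 values shown sit. The compounds shown leave open the concentration at which any of them would reach the effect in this assay, and so whether the exchanged groups differ there at all.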